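The compounds below may be only part of what the source reports. "The series", "measured", "known", "first", "only" and "open" are said of these compounds alone.

Compound 1 `O=c1[nH]/c(=C\C2CCCCC2)c(=O)[nH]/c1=C\c1cccc(Oc2ccc(F)cc2)c1` carries a cyclohexyl group on the shared core, and in a functional assay on NCI-H460 cells (Homo sapiens) for cytotoxicity, read by MTT assay, with a stated time of 72 h (a higher number here means a weaker inhibitor, a lower number a stronger inhibitor), compound 1 gives > 1000 nM, which is a limit of the assay and not a number. Among the compounds with values here, compound 2 `O=c1[nH]/c(=C\c2ccco2)c(=O)[nH]/c1=C\c1cccc(Oc2ccc(F)cc2)c1` carries furan-2-yl at that place and gives 155 nM, so compound 2 holds the only true number so far. Compound 3 `O=c1[nH]/c(=C\c2ccc(Br)o2)c(=O)[nH]/c1=C\c1cccc(Oc2ccc(F)cc2)c1` differs from compound 2 in one small way: bromo in place of hydrogen on an aromatic carbon. This is bromo in place of hydrogen on an aromatic carbon, next to the ring oxygen, turning furan-2-yl into 5-bromofuran-2-yl.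

Within the data shown here, only one measured step bears on this change: an at least 6.4-fold lower number from compound 1 to compound 2 (0.80 log units; beyond the scatter). That step exchanged a whole group, so it shows that this part of the molecule can affect the result in this assay. Among the measured compounds shown here, it does not measure what a bromo does, and no measured pair tests that swap. A step beyond the usual scatter is therefore not expected, though a slightly lower number is possible. The expected change is a 1.3-fold lower number from compound 2 to compound 3 (0.11 log units; within the scatter). For compound 3 the estimated value is 120 nM, with an expected range from 40 nM to 400 nM.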

Compound 3, half-maximal inhibitory concentration: 361 nM
Compound 3: middle estimate off by 3.0-fold (0.48 log units), on the low side; the range from low to high includes it.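

In this assay, bromo in place of hydrogen on the furan ring, next to the ring oxygen, gives a 2.3-fold higher number from compound 2 to compound 3 (0.37 log units; beyond the scatter), so this one carbon responds to the addition of a single heavy atom, and here the addition weakens the compound. The earlier step swapped a whole group, whereas this one shows that a small edit within the furan ring can also move the result beyond the usual scatter. The 5-bromofuran-2-yl group still outperforms cyclohexyl, with an at least 2.7-fold lower number from compound 1 to compound 3 (0.44 log units; beyond the scatter), so part of the gain seen with the furan ring remains once the bromo is in place, although compound 1 has a limit of the assay and not a number, which leaves the true size of that step unknown: the limit of > 1000 nM in this assay, at which 1 of the 3 values shown sits.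

A single added group cannot show whether the loss belongs to bromo itself or would follow from any group at this carbon. A chloro, a methyl or an amine at the same place would help to separate those two readings, and would show whether any group here can match or improve on the plain furan-2-yl of compound 2.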